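A few compounds are considered here, and "the series" means these few. Any claim that something is new, unique, unknown or untested is made for them only; others in the source may bear on it.

Compound 1 `O=C1CC(c2ccccc2)n2ncnc2N1` gives 51.9 mg/kg in a functional assay on the whole organism (strain Kunming) with Mus musculus as the target; a higher number here means that more compound is needed for the effect, a lower number that less compound is needed.
Compound 2 `O=C1CC(c2ccccc2F)n2ncnc2N1` gives 31.7 mg/kg in this assay.
Compound 3 `O=C1CC(c2ccccc2Cl)n2ncnc2N1` gives 25.5 mg/kg in this assay.

Among these three, compound 1 holds the highest number in this assay. Its nearest neighbour is compound 2, reached by a step of a 1.6-fold lower number from compound 1 to compound 2 (0.21 log units; within the scatter); the furthest is compound 3, reached by a 2.0-fold lower number from compound 1 to compound 3 (0.31 log units; beyond the scatter). Between the two halogenated compounds the gap is a 1.2-fold lower number from compound 2 to compound 3 (0.09 log units; within the scatter).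

Compound 4 `O=C1CC(c2cccc(Cl)c2)n2ncnc2N1` has not yet been tested in this assay. It differs from compound 1 by chloro in place of hydrogen on an aromatic carbon. Among the measured compounds shown here, the measured step that bears most directly on this change is the one from compound 1 to compound 3, which also puts chloro on an aromatic carbon; that step was a 2.0-fold lower number from compound 1 to compound 3 (0.31 log units; beyond the scatter), a modest lowering. The related step from compound 1 to compound 2, a 1.6-fold lower number from compound 1 to compound 2 (0.21 log units; within the scatter), stayed within the scatter. For the measured compounds named here, none of the measured compounds carries a substituent meta to a large group, so the expectation rests on compound 3 alone. Compound 4 is therefore expected to show a modest lowering, a 1.7-fold lower number from compound 1 to compound 4 (0.24 log units; within the scatter). A result within the scatter of the starting number would not be surprising. The estimate for compound 4 in this assay is 30 mg/kg, with a range from 15 mg/kg to 60 mg/kg.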

Compound 4, dose for half-maximal effect: 47.3 mg/kg
Beside the measured number, compound 4's estimate is 1.6-fold (0.20 log units) below it; the measured number falls inside the stated range.
By their numbers in this assay, from the lowest: compounds 3, 2, 4 and 1 (each within the scatter of the next, the first and the last beyond it).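

Placed on an aromatic carbon meta to a large group, chloro gives a 1.1-fold lower number from compound 1 to compound 4 (0.04 log units; within the scatter) in this assay, so at this position the change cannot be told apart from compound 1. The same replacement of hydrogen by chloro, at the position it holds in compound 3, gave a 2.0-fold lower number from compound 1 to compound 3 (0.31 log units; beyond the scatter), so that step, which lay beyond the scatter, does not carry over to this position, and for these two compounds the outcome of adding chloro differs with its place on the ring. No measurement shown here bears on the reason for this difference.

On these data alone, whether any other group on this aromatic carbon, such as fluoro, methoxy, an amine or a carboxylic acid, would move the number beyond the scatter remains open. Also open, as far as these compounds go, is whether replacing the amide hydrogen of the shared core with a methyl group or a longer chain would change the number in this assay, and whether such a change would hold for both chloro compounds.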